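Replacing a primary amine with a piperidine on the amide

A few compounds are considered here, and "the series" means these few. Any claim that something is new, unique, unknown or untested is made for them only; others in the source may bear on it.

Compound 1, whose structure is `N[C@@H]1CCCN(C(=O)c2ccc(-c3ccc4ncc(-c5ccc6cnccc6c5)n4c3)cc2)C1`, is tested in an assay on Sf21 cells for inhibition of MAP kinase-interacting serine/threonine-protein kinase 2 (Homo sapiens), read by luminescence and ADP-Glo, with stated times of 10 min and 40 min (a lower number here means a stronger inhibitor, a higher number a weaker inhibitor), where it gives 8.9 nM. Among the three compounds measured so far this is the lowest number. Compound 2, with the structure `NC1CCN(C(=O)c2ccc(-c3ccc4ncc(-c5ccc6cnccc6c5)n4n3)cc2)CC1`, gives 15.7 nM, a number that lies within the usual scatter of compound 1, so no order between the two can be claimed. Compound 3, with the structure `O=C(c1ccc(-c2ccc3ncc(-c4cnc5ccccc5c4)n3c2)cc1)N1CCNCC1`, gives 51.2 nM, which is clearly weaker than compound 1 and beyond the scatter.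

Compound 4, structure `O=C(c1ccc(-c2ccc3ncc(-c4ccc5cnccc5c4)n3c2)cc1)N1CCC(N2CCCCC2)CC1`, has not yet been measured. It differs from compound 1 in one place: 4-(piperidin-1-yl)piperidin-1-yl in place of 3-aminopiperidin-1-yl on a carbonyl carbon. The group that leaves carries one hydrogen-bond donor; the group that enters carries none but keeps one acceptor and adds a second ring.

Among the compounds with values here, no measured pair isolates this change. Compound 4 is therefore expected to give about 20 nM in this assay, with a likely range from 6 nM to 70 nM. This amounts to an expected step of a 2.2-fold higher number from compound 1 to compound 4 (0.35 log units; beyond the scatter), a small weakening that may well stay within the scatter.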

Compound 4, half-maximal inhibitory concentration: 1.5 nM
Estimate against measurement, compound 4: 13-fold (1.12 log units) above, and the stated range ends above it.
By their numbers in this assay, from the lowest: compound 4; then compounds 1 and 2 (each within the scatter of the next); then compound 3.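

On this carbonyl carbon, a group with no hydrogen-bond donor can do better than one with a primary amine: 4-(piperidin-1-yl)piperidin-1-yl in place of 3-aminopiperidin-1-yl gives a 5.9-fold lower number from compound 1 to compound 4 (0.77 log units; beyond the scatter) and so the donor of the leaving group is not required for a low number. The larger entering group, with its second ring, is also accepted here, and the defined stereocentre of the leaving group is not needed. No measurement available here explains why the number falls.

The step changes the donor count, the ring count and the size together, so the compounds shown cannot say which of these matters. A 4-(dimethylamino)piperidin-1-yl group on the same core would keep the entering group's outer amine without its second ring, and a 4-aminopiperidin-1-yl group would keep the donor while moving the amine.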